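Swapping the pyridine for a fluorophenyl on a shared core

This account rests on a few compounds, and the source may have more. Where it says the series, first, only, none or still open, it means among the compounds named here.

Compound 1 `Cc1csc(NC(=O)Cn2cc(-c3ccncc3)nn2)n1` is the starting point here. In a functional assay on BMDM cells (Mus musculus, strain C57BL/6) for inhibition, with a stated time of 2 days (a lower number here means a stronger inhibitor, a higher number a weaker inhibitor), compound 1 gives 100 nM. Among the three compounds measured so far, compound 1 stands second highest: compound 3 `CCOC(=O)c1sc(NC(=O)Cn2cc(-c3ccncc3)nn2)nc1C`, which gives 120 nM, is the nearest, while compound 2 `O=C(Cn1cc(-c2ccncc2)nn1)Nc1nccs1`, which gives 2 nM, is the furthest away. Both measured steps start from compound 1. There is a 50-fold lower number from compound 1 to compound 2 (1.70 log units; beyond the scatter), and there is a 1.2-fold higher number from compound 1 to compound 3 (0.08 log units; within the scatter). Each of these concerns the methyl-bearing end of the shared core.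

Compound 4 `Cc1csc(NC(=O)Cn2cc(-c3ccc(F)cc3)nn2)n1` differs from compound 1 at one place: 4-fluorophenyl in place of pyridin-4-yl on an aromatic carbon. Among the measured compounds shown here, this change sits on the five-membered ring at the far end of the core, a part of the molecule that no measured step has touched. The two known steps therefore do not bear directly on it, and they give no guide to either the size or the direction of the change. What remains is the bare fact that a ring with one hydrogen-bond acceptor is replaced by a ring with none, and that the closest measured step on this core was large. Taking that together, a moderate step toward a higher number, with wide uncertainty, is expected: a 3.0-fold higher number from compound 1 to compound 4 (0.48 log units; beyond the scatter). Compound 4 is estimated to give about 300 nM, likely falling between 60 nM and 3000 nM.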

Compound 4, half-maximal inhibitory concentration: 250 nM
The estimate for compound 4 lay 1.2-fold (0.08 log units) above the measured number, and the stated range covers the measured number.
By their numbers in this assay, from the lowest: compound 2; then compounds 1 and 3 (each within the scatter of the next); then compound 4.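

In this assay, replacing pyridin-4-yl with 4-fluorophenyl gives a 2.5-fold higher number from compound 1 to compound 4 (0.40 log units; beyond the scatter), the first measured sign that this position on the five-membered aromatic ring responds to a change of group, though only modestly. The group that enters has no hydrogen-bond acceptor where the group that leaves has one, so inhibition in this assay does not depend heavily on that acceptor on this core, and compound 4 remains an inhibitor with a number close to those of compound 1 and compound 3. The step is also much smaller than the one at the other end of the core, a 50-fold lower number from compound 1 to compound 2 (1.70 log units; beyond the scatter), which suggests that, of the changes so far, the methyl group matters more than this ring, and no measurement here explains why the number rises at this position.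

The swap removes a ring nitrogen and adds a fluorine at once, so a plain phenyl would be needed to tell those two parts apart. From the compounds shown here alone, it also remains open whether a pyridin-3-yl or a morpholine at this position would behave alike, and whether 4-fluorophenyl would cost the same on the core of compound 2.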